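The source may hold more compounds than are shown below. What is called first, only, known or untested is meant among the compounds shown, and "the series" means these compounds.

Measured compounds:
- compound 1 `CCCCc1cnc(C(Cc2ccc(-c3ccccc3C(=O)O)cc2)C(C)C)[nH]1`: 2240 nM
- compound 2 `O=C(O)c1ccccc1-c1ccc(CCc2ncc(Cc3cccc(F)c3)[nH]2)cc1`: 7.9 nM

In an in vitro functional assay on cells for agonist activity at Bombesin receptor subtype-3 (Mus musculus), read by luminescence and calcium flux (on this read-out higher numbers stand for an effect only at larger amounts of compound and lower numbers for an effect already at smaller amounts), compound 2 gives 7.9 nM, the lowest of the two numbers; compound 1 gives 2240 nM, a gap beyond the scatter. The two compounds differ in more than one place, so the gap cannot be tied to any single change.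

The next compound is compound 3 `COc1ccccc1Cc1cnc(CCc2ccc(-c3ccccc3C(=O)O)cc2)[nH]1`, not yet measured. Relative to compound 2 it carries 2-methoxyphenyl in place of 3-fluorophenyl on a saturated chain carbon bound to an aromatic carbon. Both groups are single aromatic rings of carbon without donors; the incoming one adds an acceptor. Going by the values given here, no step of this kind is available among the measured compounds, so the direction is open. A modest step is expected in this assay, if any, from compound 2 to compound 3, a 2.5-fold higher number from compound 2 to compound 3 (0.40 log units; beyond the scatter), leaning toward a somewhat higher number. For compound 3 the estimate is 20 nM, with a range from 5 nM to 80 nM.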

Compound 3, half-maximal effective concentration: 163 nM
Beside the measured number, compound 3's estimate is 8.2-fold (0.91 log units) below it, and the stated range ends below it.
By their numbers in this assay, from the lowest: compound 2; then compound 3; then compound 1.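

The group on the saturated chain carbon bound to an aromatic carbon strongly affects the read-out in this assay. Placing 2-methoxyphenyl in place of 3-fluorophenyl gives a 21-fold higher number from compound 2 to compound 3 (1.31 log units; beyond the scatter) and provides the first comparison in the series that can be tied to one place, which compound 1 and compound 2 could not provide. No measurement on these compounds accounts for the step.

The change replaces fluorine with a methoxy group and also moves the substituent, so the compounds shown do not separate the group's identity from its location on the ring. On these data alone, how plain phenyl, or a benzyl group carrying an amine, would read at this place remains open, as does whether any group here gives a number lower than that of compound 2.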